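The compounds below may be only part of what the source reports. "The series", "measured", "known", "first", "only" and "open" are said of these compounds alone.

Compound 1, `CN(C)CCCCOc1ccccc1/C=C/c1ccc(Cl)cc1`, gives 62.5% in a functional assay on the whole organism with Mus musculus as the target, at a dose of 50 mg/kg by the oral route; a higher number here means more inhibition at the dose given (going by the name of the read-out), a lower number less inhibition.
Compound 2, `CN(C)CCCCOc1ccccc1/C=C/c1ccccc1F`, gives 17% in this assay.

Within the data shown here, compound 2 stands lowest of these two numbers; the single measured step, a number 45.5 percentage points lower from compound 1 to compound 2 (beyond the scatter), is large and beyond the scatter. Compound 3, `Cc1ccccc1/C=C/c1ccccc1OCCCCN(C)C`, differs from compound 2 by methyl in place of fluoro on an aromatic carbon. Among the measured compounds shown here, no measured step tests a methyl in place of fluoro; the one known step changes both the halogen and its ring position, so it gives little guidance here. The expected step is therefore small, a number 8 percentage points higher from compound 2 to compound 3 (within the scatter), with wide uncertainty. Compound 3 is estimated at 25%, with a range from 5% to 55%.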

Compound 3, a percentage reported as inhibition, in the whole organism at one dose (the size of the read-out at that dose, not a potency): 16.7%
Compound 3: middle estimate off by 8.3 percentage points, on the high side; measured number inside the range.
By their numbers in this assay, from the lowest: compounds 3 and 2 (each within the scatter of the next); then compound 1.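

In this assay, methyl in place of fluoro on this aromatic carbon gives a number 0.3 percentage points lower from compound 2 to compound 3 (within the scatter), so the two groups cannot be told apart at this place. With either group, the distance from the 4-chlorophenyl compound remains large, as a number 45.8 percentage points lower from compound 1 to compound 3 (beyond the scatter) shows, so that distance does not depend on fluoro alone. No measurement here explains this result. The compounds shown leave open whether the chlorine or its ring position accounts for that distance, and how a 2-chlorophenyl or 2-methoxyphenyl group would read here.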